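This account rests on a few compounds, and the source may have more. Where it says the series, first, only, none or still open, it means among the compounds named here.

Compound 1 `COc1ccc(OC)c(/C=N/NC(=O)Nc2ccc(Oc3ccnc(-c4nncn4CCN(C)C)c3)c(F)c2)c1`: 1950 nM; compound 2 `COc1ccc(/C=N/NC(=O)Nc2ccc(Oc3ccnc(-c4nncn4CCN(C)C)c3)c(F)c2)cc1O`: > 100000 nM.

In a functional assay on A549 cells (Homo sapiens) for cytotoxicity, read by MTT assay, with a stated time of 72 h (a higher number here means a weaker inhibitor, a lower number a stronger inhibitor), compound 1 gives 1950 nM. Compound 2 reaches only a limit in this assay, > 100000 nM, as the limit of > 100000 nM in this assay, at which 1 of the 2 values shown sits, records. Compound 3 `CN(C)CCn1cnnc1-c1cc(Oc2ccc(NC(=O)N/N=C/c3ccc(F)cc3Cl)cc2F)ccn1` differs from compound 2 by 2-chloro-4-fluorophenyl in place of 3-hydroxy-4-methoxyphenyl on a carbon with a double bond to nitrogen. Within the data shown here, the single measured step touching the same ring, an at least 51-fold higher number from compound 1 to compound 2 (1.70 log units; beyond the scatter), was large, and compound 3 again carries a ring without a hydroxyl, so a large step back toward stronger inhibition is expected, an at least 25-fold lower number from compound 2 to compound 3 (1.39 log units; beyond the scatter), with wide uncertainty since the entering ring matches neither measured one. Compound 3 is estimated at 4000 nM, between 600 nM and 40000 nM.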

Compound 3, half-maximal inhibitory concentration: 1120 nM
Compound 3: middle estimate off by 3.6-fold (0.55 log units), on the high side, and the stated range covers the measured number.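

Placing 2-chloro-4-fluorophenyl on the carbon with a double bond to nitrogen gives an at least 89-fold lower number from compound 2 to compound 3 (1.95 log units; beyond the scatter) in this assay, yet set against 2,5-dimethoxyphenyl it gives a 1.7-fold lower number from compound 1 to compound 3 (0.24 log units; within the scatter). Two rings without a hydroxyl, one with oxygen substituents and one with halogens, thus read alike at this position, and only the 3-hydroxy-4-methoxyphenyl ring of compound 2 goes against them. Compound 2 stands at a limit, not a number: the limit of > 100000 nM in this assay, at which 1 of the 3 values shown sits.

Whether the hydroxyl alone accounts for the gap stays open. A 4-methoxyphenyl ring, or a 3-aminophenyl ring, would help separate it from the methoxy group.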